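Piperidin-4-yl for 4-hydroxyphenyl: working notes on compound 3

The source may hold more compounds than are shown below. What is called first, only, known or untested is meant among the compounds shown, and "the series" means these compounds.

Compound 1 `Oc1ccc(-c2nc(-c3c[nH]c4ccccc34)co2)cc1` gives 247000 nM in a functional assay on DU-145 cells (Homo sapiens) for cytotoxicity, read by MTT assay, with a stated time of 48 h; on this read-out higher numbers stand for weaker inhibition and lower numbers for stronger inhibition. Within the data shown here, the only other number so far belongs to compound 2 `COc1ccc(-c2nc(-c3c[nH]c4ccccc34)co2)cc1`, which gives 165000 nM in this assay, so compound 1 stands side by side with compound 2, the two numbers not separable from each other. Among the measured compounds shown here, the single measured step, a 1.5-fold lower number from compound 1 to compound 2 (0.18 log units; within the scatter), is methyl in place of hydrogen on an oxygen on an aromatic ring, and it does not touch the change now considered. Compound 3 `c1ccc2c(-c3coc(C4CCNCC4)n3)c[nH]c2c1` carries piperidin-4-yl in place of 4-hydroxyphenyl on an aromatic carbon. For the measured compounds named here, no measured pair swaps this group for another, so no step gives a direction; the range is set wide, the change being unlike any step seen. On the numbers at hand compound 3 is estimated at 200000 nM, between 50000 nM and 800000 nM. The step of a 1.2-fold lower number from compound 1 to compound 3 (0.09 log units; within the scatter) is expected to stay within the scatter.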

Compound 3, half-maximal inhibitory concentration: 381000 nM
Beside the measured number, compound 3's estimate is 1.9-fold (0.28 log units) below it; the measured number falls inside the stated range.
By their numbers in this assay, from the lowest: compounds 2, 1 and 3 (each within the scatter of the next, the first and the last beyond it).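

In this assay, piperidin-4-yl in place of 4-hydroxyphenyl on this aromatic carbon gives a 1.5-fold higher number from compound 1 to compound 3 (0.19 log units; within the scatter). Among these compounds, this is the first measured change at this place, and it swaps one six-membered aromatic ring of carbon only for one six-membered non-aromatic ring with 1 hetero atom, yet compound 1 and compound 3 cannot be told apart in this assay. The aromatic ring of 4-hydroxyphenyl is therefore not needed here to hold the number of compound 1, though no information on hand accounts for this result.

From the compounds shown here alone, whether a methyl on the piperidine nitrogen would move the number beyond the scatter remains open. The same holds for an open-chain amine or a carboxylic acid at this place.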